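The source may report more compounds than this note shows. Statements on the series, on what has been measured and on what is new or still open speak of the compounds shown alone.

Two esters that share one core have been tested so far in an ADME assay on HepG2 2.2.15 cells (Homo sapiens) for cytotoxicity; on this read-out higher numbers stand for lower toxicity in this test and lower numbers for higher toxicity in this test. Compound 1 `CCCCCCCC(=O)OCCc1c(-c2ccccc2Cl)c2cc(Cl)ccc2[nH]c1=O` gives 78000 nM, and compound 2 `O=C(CN1C(=O)c2ccccc2C1=O)OCCc1c(-c2ccccc2Cl)c2cc(Cl)ccc2[nH]c1=O` gives 960000 nM, the higher of the two numbers. Compound 3 `COc1cccc(/C=C/C(=O)OCCc2c(-c3ccccc3Cl)c3cc(Cl)ccc3[nH]c2=O)c1` keeps the shared core and changes only the group on the carbonyl carbon: a group of 10 heavy atoms (9 carbon, 1 oxygen; one six-membered aromatic ring of carbon only) in place of a group of 12 heavy atoms (9 carbon, 1 nitrogen, 2 oxygen; one five-membered non-aromatic ring with 1 hetero atom, one six-membered aromatic ring of carbon only), on a carbonyl carbon. Going by the values given here, only one measured step bears on this change, a 12-fold higher number from compound 1 to compound 2 (1.09 log units; beyond the scatter), and it too swaps the group attached through that carbonyl carbon. That large step shows that the numbers in this assay can shift strongly with this group. The group in compound 3 lacks the five-membered non-aromatic ring of compound 2 but keeps a six-membered aromatic ring of carbon only, so it matches neither earlier group fully. Among the compounds with values here, a move back towards lower numbers is therefore expected, smaller than the one measured step. The estimated step is a 4.8-fold lower number from compound 2 to compound 3 (0.68 log units; beyond the scatter). Compound 3 is expected to give 200000 nM, with a likely range from 60000 nM to 600000 nM.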

Compound 3, half-maximal cytotoxic concentration: > 1300000 nM
Compound 3: a limit, no number; the forecaster's own chance of this, stated with the estimate: 10%; middle value at least 6.5-fold (0.81 log units) from the limit.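

Compound 3 in this assay gives > 1300000 nM, which is a limit of the test and not an exact number: the limit of > 1300000 nM in this assay, at which 1 of the 3 values shown sits. Read against compound 2, this gives an at least 1.3-fold higher number from compound 2 to compound 3 (0.13 log units; that floor lies within the scatter), only a floor for the gap, so the two compounds cannot be put in order. Read against the heptyl ester, it gives an at least 16-fold higher number from compound 1 to compound 3 (1.22 log units; beyond the scatter), close to the size of a 12-fold higher number from compound 1 to compound 2 (1.09 log units; beyond the scatter), so on this carbonyl carbon a high number does not depend on the five-membered non-aromatic ring of compound 2, and among these three esters only the heptyl one, compound 1, stands apart at the low end.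

The compounds shown do not tell whether the methoxy group or the double bond of 2-(3-methoxyphenyl)ethenyl plays any part, which a plain 2-phenylethenyl or a saturated 2-(3-methoxyphenyl)ethyl group would help to separate. As far as these compounds go, it also stays open whether the lower number of compound 1 follows the length of its chain, a question that a butyl chain or a longer dodecyl chain in the same place could address.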